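The source may report more compounds than this note shows. Statements on the series, on what has been measured and on what is new or still open speak of the compounds shown alone.

Compound 1 `CN1CCCC(n2cc(S(=O)(=O)c3cccc4ccccc34)c3ccccc32)C1`, 7.1 nM; compound 2 `O=S(=O)(c1cccc(F)c1)c1cn(C2CCNC2)c2cc(Cl)ccc12`, 72 nM; compound 3 `O=S(=O)(c1cccc(F)c1)c1cn(C2CCCNC2)c2ccc(F)cc12`, 4 nM.

These three were measured in an assay on HeLa cells for displacement of a labelled ligand from 5-hydroxytryptamine receptor 6 (Homo sapiens), with a stated time of 2 h; a lower number here means a stronger inhibitor, a higher number a weaker inhibitor. Among them compound 1 has the second highest number; its nearest neighbour is compound 3, whose number lies within the scatter of its own, while compound 2 gives a higher number, a gap beyond the scatter. Compound 4 `O=S(=O)(c1cccc2ccccc12)c1cn(C2CCCNC2)c2ccccc12` has not been measured. It differs from compound 1 in one place: hydrogen in place of methyl on an amine nitrogen in a ring. Going by the values given here, no measured pair shows this exact change, so the size of the step is uncertain. Compound 3, which also carries a piperidin-3-yl, gives 4 nM, and on that basis the step of a 1.4-fold lower number from compound 1 to compound 4 (0.15 log units; within the scatter) is expected to stay within the scatter. Compound 4 is therefore estimated at 5 nM, with a range from 1.5 nM to 15 nM.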

Compound 4, inhibition constant: 21 nM
Compound 4: middle estimate off by 4.2-fold (0.62 log units), on the low side; measured number outside the range, above it.
By their numbers in this assay, from the lowest: compounds 3 and 1 (each within the scatter of the next); then compound 4; then compound 2.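

In this assay, going by these compounds alone, this is the first single change that can be read on its own, and the ring nitrogen proves not to be indifferent to what it carries: a 3.0-fold higher number from compound 1 to compound 4 (0.47 log units; beyond the scatter) is a modest step, but beyond the scatter. Here, 1-methylpiperidin-3-yl gives the stronger inhibitor than piperidin-3-yl. Nothing available explains this step. Still open, as far as these compounds go, is how an ethyl group or a longer chain on this nitrogen would behave, and whether the methyl gives the same step on other cores.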